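The source may hold more compounds than are shown below. What is called first, only, known or untested is meant among the compounds shown, and "the series" means these compounds.

Measured in an ADME assay on MT4 cells (Homo sapiens) for cytotoxicity, read by MTT assay; on this read-out higher numbers stand for lower toxicity in this test and lower numbers for higher toxicity in this test:

- compound 3 `CC(C)(C)c1ccc(Cn2cc(C(=O)C3=C(O)C(=O)OC3)c3cc(Cl)ccc32)cc1` gives 53000 nM
- compound 1 `O=C(O)/C(O)=C/C(=O)c1cn(Cc2ccc(C(F)(F)F)cc2)c2ccc(Cl)cc12` gives 23000 nM
- compound 2 `Cc1cc(C)cc(Cn2cc(C(=O)/C=C(\O)C(=O)O)c3cc(Cl)ccc32)c1` reaches only a limit, reported as > 125000 nM

Among the compounds with values here, compound 3 stands at the highest of the two numbers so far in this assay; the nearest number is that of compound 1, which sits lower by a gap beyond the usual scatter. Compound 2 is not a number but a limit, so its place relative to compound 3 cannot be fixed. Within the data shown here, the one sharp comparison available is therefore compound 3 against compound 1.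

Compound 4 `Cc1cc(C)cc(Cn2cc(C(=O)C3=C(O)C(=O)OC3)c3cc(Cl)ccc32)c1` is the next compound: 3,5-dimethylphenyl in place of 4-(tert-butyl)phenyl on a saturated chain carbon bound to an aromatic nitrogen. Nothing measured isolates this change on the core of compound 3. What is known is that compound 2, which carries the same 3,5-dimethylphenyl group on a related core, reached only a limit in this assay. On that basis the step from compound 3 to compound 4 is expected to be upward, that is toward a higher number and lower toxicity in this assay, with an expected size of a 1.8-fold higher number from compound 3 to compound 4 (0.25 log units; within the scatter). Compound 4 is expected to give about 95000 nM, within 40000 nM to 220000 nM, with a real chance that only a limit is returned.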

Compound 4, half-maximal cytotoxic concentration: 53500 nM
For compound 4 the middle estimate is 1.8-fold (0.25 log units) above the measured one, and the stated range covers the measured number.
By their numbers in this assay, from the lowest: compound 1; then compounds 3 and 4 (each within the scatter of the next). At a limit, above all of these: compound 2.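

In this assay, 3,5-dimethylphenyl in place of 4-(tert-butyl)phenyl on a saturated chain carbon bound to an aromatic nitrogen leaves the read-out unresolved on this core: a 1.0-fold higher number from compound 3 to compound 4 (0.00 log units; within the scatter). With 3,5-dimethylphenyl held constant, changing the group on the carbonyl carbon gives a step beyond the scatter, so in this one pair the change on the carbonyl carbon registers where the change on the chain carbon does not: an at least 2.3-fold lower number from compound 2 to compound 4 (0.36 log units; beyond the scatter). Compound 2 gives a limit and not a number: the limit of > 125000 nM in this assay, at which 1 of the 4 values shown sits.

It remains open whether the change on the carbonyl carbon has the same outcome with any other group on the chain carbon, since only one such pair is shown. Also open, going by these compounds, is what a morpholine or a longer chain in place of 3,5-dimethylphenyl would give.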